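Pyridyl in Place of Methoxyphenyl on a Weak Core

The source may hold more compounds than are shown below. What is called first, only, known or untested is meant among the compounds shown, and "the series" means these compounds.

In a functional assay on CHO cells for antagonist activity at adenosine receptor A2b (Homo sapiens), read by 33P incorporation, with a stated time of 20 min (on this read-out lower numbers stand for stronger inhibition and higher numbers for weaker inhibition), compound 1 (`COc1ccc(-c2nc3c(NC4CCCC4)ncnc3n2C)cc1`) reaches only the limit of the assay, > 30000 nM, so no number is known for it. Compound 2 (`Cn1c(-c2ccc(C(=O)O)cc2)nc2c(NC3CCCC3)ncnc21`) likewise stops at the limit, > 30000 nM. The step that the two limits leave unreadable from compound 1 to compound 2 therefore cannot be sized because both ends sit at the limit of > 30000 nM in this assay, at which 2 of the 3 values shown sit. Compound 3 (`CCCn1c(-c2ccccc2)nc2c(NC3CCCCC3)ncnc21`) differs from compound 1 in more than one place; of the set, only compound 3 has a numerical value, 5310 nM.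

Compound 4 (`Cn1c(-c2cccnc2)nc2c(NC3CCCC3)ncnc21`) differs from compound 1 by a single exchange: pyridin-3-yl in place of 4-methoxyphenyl on an aromatic carbon. For the measured compounds named here, no measured step speaks directly to this exchange, and the one step that is measured, on the same ring of the core, is unreadable. With compound 1 at the limit, compound 4 is expected to stay weak, and the step from compound 1 to compound 4 is estimated as a number no higher from compound 1 to compound 4 (the limit leaves the size open). For compound 4 the estimate is 30000 nM, with a range from 6000 nM to 150000 nM.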

Compound 4, inhibition constant: > 30000 nM
Compound 4 gave a limit, no number (the forecaster's own chance of this, stated with the estimate: 60%); the middle value sits exactly at the limit.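

Compound 4, like compound 1, ends at a limit and not a number, so no step between them can be read, because both stand at the same point: the limit of > 30000 nM in this assay, at which 3 of the 4 values shown sit.

The compounds shown leave open whether pyridin-3-yl or 4-methoxyphenyl gives stronger inhibition on this shared core, and by how much.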